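Series notes: cytotoxicity values sitting at the assay limits

The compounds below may be only part of what the source reports. "The series", "measured", "known", "first", "only" and "open" are said of these compounds alone.

The shared core is carried by compound 1 `CC1CCN(C2CCN(S(=O)(=O)c3ccc(OCc4ccccc4)cc3)CC2)CC1`, compound 2 `CC1CCN(C2CCN(S(=O)(=O)c3nccn3C)CC2)CC1` and compound 3 `CC1CCN(C2CCN(S(=O)(=O)c3ccccc3-c3ccc(Cl)cc3)CC2)CC1`, each with a different sulfonyl-linked aromatic group. In an ADME assay on HCT-116 cells (Homo sapiens) for cytotoxicity, read by CellTiter-Glo, with a stated time of 72 h (on this read-out higher numbers stand for weaker inhibition and lower numbers for stronger inhibition), compound 1 gives > 5000 nM, which is a limit of the assay and not a number. Compound 2 gives > 10000 nM in this assay, again a limit rather than a measured number. Compound 3 gives > 5000 nM in this assay, also a limit. Compound 1 therefore stands among values that are all limits: the limit of > 5000 nM in this assay, at which 2 of the 3 values shown sit, and the limit of > 10000 nM in this assay, at which 1 of the 3 values shown sits, account for everything measured so far, and no order between compound 1, compound 2 and compound 3 can be read from them.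

Compound 4 `CC1CCN(C2CCN(S(=O)(=O)c3ccc(-c4ccc(Cl)cc4)cc3)CC2)CC1` has not been measured in this assay. It differs from compound 1 by 4-chlorophenyl in place of benzyloxy on an aromatic carbon. Compound 3, which also carries a 4-chlorophenyl on the shared core, returns only a limit in this assay. On that basis no step beyond the scatter is expected in this assay, and the expected step from compound 1 to compound 4 is a step that the limit leaves unreadable from compound 1 to compound 4. For compound 4 the estimated value in this assay is 7000 nM, within a range from 2500 nM to 20000 nM, and a further limit rather than a number is the most likely outcome.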

Compound 4, half-maximal inhibitory concentration: > 5000 nM
Compound 4 was reported as a limit; the forecaster's own chance of this, stated with the estimate: 80%; the middle value is on the limit's open side.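

In this assay compound 4 gives > 5000 nM, a limit of the assay. Among the compounds shown here, compound 1 also returns only a limit, so no step between compound 1 and compound 4 can be read. How compound 1, compound 2, compound 3 and compound 4 rank as measured numbers in this assay stays open, with every value a limit: the limit of > 5000 nM in this assay, at which 3 of the 4 values shown sit.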